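The source may report more compounds than this note shows. Statements on the series, on what has been measured and on what is new or still open speak of the compounds shown alone.

Compound 1 `CCCS(=O)(=O)NC(=O)c1cc(COc2ccc(-c3ccc(OC)cc3)cc2)c(C)o1` is one of two compounds in this set with a solubility reading. In a physicochemical assay for solubility, in phosphate buffer, with a stated time of 24 h, at pH 7.4 (on this read-out higher numbers stand for higher solubility and lower numbers for lower solubility), compound 1 gives 7 ug/mL, the lowest of the two numbers. Compound 2 `COc1ccc(-c2ccc(OCc3cc(C(=O)NS(=O)(=O)c4c(C)noc4C)oc3C)cc2)nc1` is the other measured compound, and in this assay compound 2 gives 90 ug/mL, a value separated from compound 1 by a gap that lies beyond the usual scatter. Since compound 2 differs from compound 1 in more than one place, nothing is shown about the effect of any single change, and the gap can only be stated as what the two values show.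

Compound 3 `COc1ccc(-c2ccc(OCc3cc(C(=O)NS(=O)(=O)c4ccccc4)oc3C)cc2)cc1` has not been measured. It differs from compound 1 in one place: phenyl in place of propyl on a sulfonyl sulfur. Going by the values given here, no single-change step between measured compounds is available to guide the expectation. Compound 3 is therefore expected to stay near compound 1, and the step from compound 1 to compound 3 is estimated at a 1.4-fold lower number from compound 1 to compound 3 (0.15 log units; within the scatter), a change not clearly beyond the scatter. For compound 3 the expected value in this assay is 5 ug/mL, with a likely range from 1.5 ug/mL to 15 ug/mL.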

Compound 3, solubility: 11 ug/mL
For compound 3 the middle estimate is 2.2-fold (0.34 log units) below the measured one; measured number inside the range.
By their numbers in this assay, from the lowest: compounds 1 and 3 (each within the scatter of the next); then compound 2.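

In this assay, going by these compounds alone, phenyl in place of propyl on a sulfonyl sulfur gives a 1.6-fold higher number from compound 1 to compound 3 (0.20 log units; within the scatter), the first single-change step in this set. At this position, then, the read-out does not separate the phenyl group from the propyl group, even though this change brings in a six-membered aromatic ring of carbon only. Nothing shown here offers an explanation for this result.

As far as these compounds go, it remains open whether an amine, a carboxylic acid or a longer chain on the same sulfonyl sulfur would give a step beyond the scatter. From the compounds shown here alone, it also remains open whether phenyl in place of propyl would give a similar step on a core other than that of compound 1.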